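From 2-nitrophenyl to 3-methylphenyl on the shared core

A few compounds are considered here, and "the series" means these few. Any claim that something is new, unique, unknown or untested is made for them only; others in the source may bear on it.

Compound 1 `CC1=NN(c2ccccc2)C(=O)[C@@]12C(=O)C=CC[C@@H]2c1ccccc1[N+](=O)[O-]` gives 66800 nM
Compound 2 `CC1=NN(c2ccccc2)C(=O)[C@@]12C(=O)C=CC[C@H]2c1ccc(C)cc1` gives 5210 nM
Compound 3 `CC1=NN(c2ccccc2)C(=O)[C@]12C(=O)C=CC[C@H]2c1cccc(C)c1` gives 9580 nM

These values come from a functional assay on HCT-116 cells (Homo sapiens) for inhibition, read by MTT assay, with a stated time of 72 h (on this read-out higher numbers stand for weaker inhibition and lower numbers for stronger inhibition), and compound 1 at 66800 nM stands highest of the three numbers. Its gaps to the other two lie beyond the scatter, so it shows the weakest inhibition of the three. Compound 2 at 5210 nM and compound 3 at 9580 nM lie within the scatter of each other.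

The change from compound 1 to compound 4 `CC1=NN(c2ccccc2)C(=O)[C@@]12C(=O)C=CC[C@@H]2c1cccc(C)c1` is 3-methylphenyl in place of 2-nitrophenyl on a saturated ring carbon with 3-methylphenyl in place of 2-nitrophenyl on a saturated ring carbon. Among the measured compounds shown here, no measured pair isolates this change. Compound 3 carries the same 3-methylphenyl and gives 9580 nM in this assay so a lower number than that of compound 1 is expected for compound 4, with a step beyond the scatter. The estimated change is a 6.7-fold lower number from compound 1 to compound 4 (0.82 log units; beyond the scatter) towards stronger inhibition. Resting on this single comparison, the expected value for compound 4 is 10000 nM with an estimated range of 3500 nM to 30000 nM on this read-out.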

Compound 4, half-maximal inhibitory concentration: 3800 nM
For compound 4 the middle estimate is 2.6-fold (0.42 log units) above the measured one; the measured number falls inside the stated range.
By their numbers in this assay, from the lowest: compounds 4, 2 and 3 (each within the scatter of the next, the first and the last beyond it); then compound 1.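

Swapping 2-nitrophenyl for 3-methylphenyl on the saturated ring carbon, with no other change, gives an 18-fold lower number from compound 1 to compound 4 (1.24 log units; beyond the scatter) in this assay, so the effect of this change now rests on a measured pair. The aryl group is not the only variable at this position, since the mirror-image pair gives a 2.5-fold lower number from compound 3 to compound 4 (0.40 log units; beyond the scatter), a modest step but one that lies beyond the scatter. That step can be attributed to configuration alone because of this: the fact that compounds 3 and 4 differ only in the configuration as drawn

Going by these compounds, both stereocentres are inverted between the two compounds, so which of them carries the step remains open. Also open, on these data alone, is how a group such as an amine or a carboxylic acid on the phenyl ring at this saturated ring carbon would compare with the 3-methylphenyl of compound 4 at 3800 nM.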